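Moving a fluorine on the benzyl ether of a quinazoline urea

A few compounds are considered here, and "the series" means these few. Any claim that something is new, unique, unknown or untested is made for them only; others in the source may bear on it.

Compound 1, `O=C(Nc1ccc(Cl)c(Cl)c1)Nc1cc2ncncc2cc1OCc1cccc(F)c1`: 7400 nM
Compound 2, `O=C(Nc1ccccc1F)Nc1cc2ncncc2cc1OCc1ccccc1F`: 10000 nM

Of the compounds shown here, two have been measured so far in an ADME assay on cells (Astrocyte, Homo sapiens) for cytotoxicity, read by WST assay, with a stated time of 72 h; on this read-out lower numbers stand for stronger inhibition and higher numbers for weaker inhibition. Compound 1 `O=C(Nc1ccc(Cl)c(Cl)c1)Nc1cc2ncncc2cc1OCc1cccc(F)c1` gives 7400 nM in this assay. Compound 2 `O=C(Nc1ccccc1F)Nc1cc2ncncc2cc1OCc1ccccc1F` gives 10000 nM in this assay, the higher of the two numbers, though the gap to compound 1 lies within the scatter of repeated measurements, so the two cannot be told apart.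

Compound 3 `O=C(Nc1ccccc1F)Nc1cc2ncncc2cc1OCc1cccc(F)c1` has not yet been measured. It keeps every atom of compound 2 and differs only in how they are joined: 3-fluorophenyl in place of 2-fluorophenyl on a saturated chain carbon bound to an oxygen on an aromatic ring. The benzyl ether of compound 3 matches that of compound 1, while the urea side matches compound 2. Among the compounds with values here, no measured pair isolates this change, so nothing directly shows how large a step it brings.

Since compound 1 and compound 2 sit within the scatter of each other, no step beyond the scatter is expected from compound 2 to compound 3 in this assay, in either direction. Compound 3 is therefore estimated at 8500 nM, with a likely range from 3500 nM to 20000 nM, a step of a 1.2-fold lower number from compound 2 to compound 3 (0.07 log units; within the scatter).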

Compound 3, half-maximal inhibitory concentration: > 10000 nM
Compound 3: a limit, no number; the forecaster's own chance of this, stated with the estimate: 10%; middle value at least 1.1-fold (0.07 log units) away from the limit.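

In this assay, within the data shown here, compound 3 stands at a limit of the assay, > 10000 nM, and this is not a number. 3-fluorophenyl in place of 2-fluorophenyl on a saturated chain carbon bound to an oxygen on an aromatic ring gives a number no lower from compound 2 to compound 3 (the limit leaves the size open), and the size of this step cannot be read because the value is only a limit: the limit of > 10000 nM in this assay, at which 1 of the 3 values shown sits. The result also supplies the first comparison on the urea side, where 2-fluorophenyl in place of 3,4-dichlorophenyl on an amide-type nitrogen gives an at least 1.3-fold higher number from compound 1 to compound 3 (0.13 log units; that floor lies within the scatter), and since this is only a floor, the true size of the step may or may not lie beyond the scatter.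

The compounds shown leave open where the number for compound 3 actually lies, and so how large either change really is. They also leave open whether a carboxylic acid or an amine in place of the fluorine on the benzyl ether would bring a clearly lower number in this assay.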